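The compounds below may be only part of what the source reports. "The series", "measured", "known", "first", "only" and "open" are said of these compounds alone.

Of the compounds shown here, two have been measured so far for how strongly they block an enzyme. Compound 1 `COc1ccc(N)c(C(=O)CCNC(=O)C2CC2)c1` gives, in an assay for inhibition of Nitric oxide synthase, inducible (Homo sapiens), read by scintillation counting, with a stated time of 30 min, tested at 1 mM (on this read-out higher numbers stand for more inhibition at the one concentration tested (going by the name of the read-out) and lower numbers for less inhibition), 2.66%. Compound 2 `Nc1ccc(Cl)cc1C(=O)CCNC(=O)C1CC1`, which carries chloro in place of methoxy on an aromatic carbon, gives in this assay 5.37%. The step of a number 2.7 percentage points higher from compound 1 to compound 2 (within the scatter) is within the scatter, so the two numbers cannot be told apart, and both are small. Compound 2 thus stands at a low level, alongside compound 1, with nothing to separate the two.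

Compound 3 `CCNC(=O)NCCC(=O)c1cc(Cl)ccc1N` differs from compound 2 in one place: ethylamino in place of cyclopropyl on a carbonyl carbon. For the measured compounds named here, the only measured step, a number 2.7 percentage points higher from compound 1 to compound 2 (within the scatter), concerns a group on the aromatic ring, not the carbonyl carbon where this change sits, so no measured step bears directly on it. What remains is that both measured compounds show little inhibition, and that a single change elsewhere did not move the number beyond the scatter. Compound 3 is therefore expected to show little inhibition as well, with an expected step of a number 0.4 percentage points lower from compound 2 to compound 3 (within the scatter) that stays within the scatter. The estimate for compound 3 is 5%, with a range from -6% to 16%.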

Compound 3, a percentage reported as inhibition, at one concentration (the size of the read-out at that concentration, not a potency): 78.6%
For compound 3 the middle estimate is 73.6 percentage points below the measured one; the whole stated range lies below it.
By their numbers in this assay, from the lowest: compounds 1 and 2 (each within the scatter of the next); then compound 3.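

Putting ethylamino in place of cyclopropyl on this carbonyl carbon gives a number 73.2 percentage points higher from compound 2 to compound 3 (beyond the scatter) in this assay, so this position can change the read-out strongly, which the earlier change on an aromatic carbon, a number 2.7 percentage points higher from compound 1 to compound 2 (within the scatter), gave no sign of. By heavy-atom count the two groups are the same size, so that count alone does not separate compound 2 from compound 3. The change does several things at once: it removes the three-membered ring and adds a nitrogen and a hydrogen-bond donor, and this single pair cannot show which of these differences matters.

Nothing available here explains why the step is so large.

Cyclopropylamino on the same carbonyl carbon would keep the ring while adding the nitrogen, whereas a plain propyl group would remove the ring without adding one, so these two groups could begin to pull the differences apart. As far as these compounds go, it also remains open whether ethylamino gives a similar step when methoxy replaces chloro on the aromatic carbon, and how longer chains such as butylamino behave at this position.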